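A Chloro Replaces a Methyl on Compound 2

The compounds below may be only part of what the source reports. "The series", "measured", "known", "first", "only" and "open" are said of these compounds alone.

Two measured compounds share one core and differ only in the aryl group attached to a carbonyl carbon. Compound 1 `COc1cc2ncnc(NNC(=S)NC(=O)c3ccccc3C)c2cc1OC` carries a 2-methylphenyl there, while compound 2 `COc1cc2ncnc(NNC(=S)NC(=O)c3ccc(C)cc3)c2cc1OC` carries a 4-methylphenyl. In a functional assay on MCF7 cells (Homo sapiens) for cytotoxicity, read by MTT assay, with a stated time of 72 h (a lower number here means a stronger inhibitor, a higher number a weaker inhibitor), compound 1 gives 19300 nM, and compound 2 gives 22300 nM. The step of a 1.2-fold higher number from compound 1 to compound 2 (0.06 log units; within the scatter) lies within the scatter, so the two compounds are read as alike; compound 2 holds the higher of the two numbers, but that gap carries no weight.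

Compound 3 `COc1cc2ncnc(NNC(=S)NC(=O)c3ccc(Cl)cc3)c2cc1OC` is the next compound to be measured. Its difference from compound 2 is chloro in place of methyl on an aromatic carbon. Within the data shown here, no measured step exchanges a methyl for a chloro on this ring. Among the measured compounds shown here, the only measured step, a 1.2-fold higher number from compound 1 to compound 2 (0.06 log units; within the scatter), puts 4-methylphenyl in place of 2-methylphenyl and stays within the scatter, so it gives no direction for the new change. Compound 3 is therefore expected to land close to compound 2, with a step of a 1.1-fold lower number from compound 2 to compound 3 (0.05 log units; within the scatter) that is not expected to exceed the scatter. The estimate for compound 3 in this assay is 20000 nM, with a range from 8000 nM to 50000 nM.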

Compound 3, half-maximal inhibitory concentration: 8940 nM
Beside the measured number, compound 3's estimate is 2.2-fold (0.35 log units) above it; low and high end bracket the measured number.
By their numbers in this assay, from the lowest: compound 3; then compounds 1 and 2 (each within the scatter of the next).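

In this assay, among these compounds, chloro in place of methyl on an aromatic carbon para to a large group gives a 2.5-fold lower number from compound 2 to compound 3 (0.40 log units; beyond the scatter), the first step to lie beyond the scatter, though it is modest. This shows that the number at this position responds to the identity of the group, which the earlier pair could not show. The step of a 2.2-fold lower number from compound 1 to compound 3 (0.33 log units; beyond the scatter), also modest and beyond the scatter, points the same way, whereas the step of a 1.2-fold higher number from compound 1 to compound 2 (0.06 log units; within the scatter), which changes the aryl group from 2-methylphenyl to 4-methylphenyl, stays within the scatter. No measurement shown here explains why the 4-chlorophenyl compound gives the lower number.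

On these data alone, whether a fluoro, a bromo, a methoxy or an amine on the same aromatic carbon would carry the number lower still, or back up, remains open. As far as these compounds go, it is also open whether chloro in place of methyl would give a similar step on the ring of compound 1, where the methyl sits elsewhere, and whether the step holds in cells other than these.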